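Compound 3 to compound 4: a 2,3-dimethylphenyl swap

The source may report more compounds than this note shows. Statements on the series, on what has been measured and on what is new or still open speak of the compounds shown alone.

In a functional assay on KBVIN cells (Homo sapiens) for antiproliferative activity, read by sulforhodamine B assay, with a stated time of 3 days (on this read-out higher numbers stand for an effect only at larger amounts of compound and lower numbers for an effect already at smaller amounts), three compounds on the shared core have been measured. Compound 1 `CCC1=C(O)c2c(oc(-c3ccc(Br)cc3)cc2=O)C(CC)(CC)C1=O` gives 15.7 uM, compound 2 `CCC1=C(O)c2c(oc(-c3ccc(OC)c(F)c3)cc2=O)C(CC)(CC)C1=O` gives 0.1 uM, and compound 3 `CCC1=C(O)c2c(oc(-c3ccc(OC)c(Cl)c3)cc2=O)C(CC)(CC)C1=O` gives 1.37 uM, the second highest of the three numbers. Compound 4 `CCC1=C(O)c2c(oc(-c3cccc(C)c3C)cc2=O)C(CC)(CC)C1=O` has 2,3-dimethylphenyl in place of 3-chloro-4-methoxyphenyl on an aromatic carbon.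

All measured steps at this carbon are large: an 11-fold lower number from compound 1 to compound 3 (1.06 log units; beyond the scatter), a 160-fold lower number from compound 1 to compound 2 (2.20 log units; beyond the scatter) and, with only the halogen exchanged, a 14-fold higher number from compound 2 to compound 3 (1.14 log units; beyond the scatter). The group is therefore one to which this assay responds strongly. Compound 4 shares with compound 1 the absence of a methoxy group, and both methoxy-bearing compounds have lower numbers than compound 1, with no exception among these three. Going by the values given here, no measured compound carries a methyl group on this ring, so the comparison is loose. A moderate rise is expected, giving an expected 3.6-fold higher number from compound 3 to compound 4 (0.56 log units; beyond the scatter). For compound 4 the estimate is 5 uM, with an expected range of 1 uM to 20 uM.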

Compound 4, concentration for half-maximal effect: 0.85 uM
Compound 4: middle estimate off by 5.9-fold (0.77 log units), on the high side; measured number outside the range, below it.
By their numbers in this assay, from the lowest: compound 2; then compounds 4 and 3 (each within the scatter of the next); then compound 1.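

In this assay a methoxy group proves not to be needed for a low number: 2,3-dimethylphenyl holds no methoxy group and no halogen, and the exchange still gives an 18-fold lower number from compound 1 to compound 4 (1.27 log units; beyond the scatter) at this carbon. Two quite different groups cannot be told apart here, since the swap gives a 1.6-fold lower number from compound 3 to compound 4 (0.21 log units; within the scatter) and so leaves the number within the scatter. The 3-fluoro-4-methoxyphenyl group remains apart, with an 8.5-fold higher number from compound 2 to compound 4 (0.93 log units; beyond the scatter) on going to the dimethyl ring. Nothing at hand explains these differences. Still open, going by these compounds, is how a phenyl ring with a single methyl group would compare with 2,3-dimethylphenyl, and how a phenyl ring bearing an amine or a carboxylic acid would read at this carbon.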